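Fluoro added to the pyridine ring of compound 3

This account rests on a few compounds, and the source may have more. Where it says the series, first, only, none or still open, it means among the compounds named here.

Measured so far in a functional assay for antagonist activity at transient receptor potential cation channel subfamily V member 1 (Homo sapiens), read by FLIPR; a lower number here means a stronger inhibitor, a higher number a weaker inhibitor:
compound 1 `Cc1cccnc1-c1ccc(C(=O)Nc2ccc(F)cc2)cc1`, > 4000 nM
compound 2 `Cc1cccnc1-c1ccc(C(=O)Nc2ccc(C(C)(C)C)cc2)cc1`, 11 nM
compound 3 `CC(C)(C)c1ccc(NC(=O)c2ccc(-c3ccccn3)cc2)cc1`, 11 nM

The value of compound 1 is a limit of the assay and not a number (the limit of > 4000 nM in this assay, at which 1 of the 3 values shown sits). From compound 1 to compound 2 the change is an at least 360-fold lower number from compound 1 to compound 2 (2.56 log units; beyond the scatter), with tert-butyl in place of fluoro on the anilide ring. From compound 2 to compound 3 the change is no change at the digits printed from compound 2 to compound 3 (within the scatter), with hydrogen in place of methyl on the pyridine ring. Compound 3 therefore stands level with compound 2 at the digits shown; the only other value in the set is the limit of compound 1.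

Compound 4 `CC(C)(C)c1ccc(NC(=O)c2ccc(-c3ncccc3F)cc2)cc1` differs from compound 3 by fluoro in place of hydrogen on an aromatic carbon. Among the measured compounds shown here, of the measured steps, only the one from compound 2 to compound 3 touches the pyridine ring, and it was within the scatter; the large step from compound 1 to compound 2 concerns the anilide ring and does not bear on this position. For the measured compounds named here, no measured step adds fluoro to the pyridine ring. The expectation for compound 4 is therefore a step of a 1.2-fold higher number from compound 3 to compound 4 (0.07 log units; within the scatter), within the scatter. Compound 4 is estimated at 13 nM, in the range 5 nM to 40 nM.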

Compound 4, half-maximal inhibitory concentration: 3 nM
Estimate against measurement, compound 4: 4.3-fold (0.64 log units) above, outside the stated range (below it).
By their numbers in this assay, from the lowest: compound 4; then compounds 2 and 3 (each within the scatter of the next). At a limit, above all of these: compound 1.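

In this assay, the place on the pyridine ring ortho to a large group and two atoms from the ring nitrogen proves responsive: pyridin-2-yl to 3-fluoropyridin-2-yl gives a 3.7-fold lower number from compound 3 to compound 4 (0.56 log units; beyond the scatter) and thus a step beyond the scatter, where the earlier exchange at this place gave only no change at the digits printed from compound 2 to compound 3 (within the scatter) and showed no such response. Fluoro also separates from methyl at the same place, with a 3.7-fold lower number from compound 2 to compound 4 (0.56 log units; beyond the scatter) in this comparison, so hydrogen and methyl sit level here while fluoro alone gives a lower number among the three groups shown. The compounds shown give no measured reason for this step.

Going by these compounds, whether chloro, trifluoromethyl, methoxy or an amine at this place would match or pass fluoro stays open, as does the outcome of fluoro at the other carbons of the pyridine ring. On these data alone, all three pyridine variants compared here carry the tert-butyl anilide, so it also stays open whether the step from fluoro holds with another group, such as isopropyl or trifluoromethyl, in place of tert-butyl.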